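Tolerance in the bicyclic amine series after removing chloro

The source may hold more compounds than are shown below. What is called first, only, known or untested is meant among the compounds shown, and "the series" means these compounds.

Compound 1 `C=C(C)c1csc(CN[C@@H]2C[C@H]3C[C@@H]([C@H]2C)C3(C)C)c1` and compound 2 `C[C@H]1[C@H](NCc2ccc(Cl)s2)C[C@H]2C[C@@H]1C2(C)C` share the same core and differ only in the aromatic group carried on the amine arm. In an ADME assay on MDCK cells (Canis lupus familiaris) for cytotoxicity, read by microscopy, with a stated time of 48 h (a higher number here means that more compound is tolerated, a lower number that less compound is tolerated), compound 1 gives 25000 nM. In this assay, for the measured compounds named here, compound 2 gives 25000 nM, level with compound 1 at the digits recorded and within the scatter of the method; no step between these two is sized here, so their values show only that both are tolerated to the same extent.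

Compound 3 `C[C@H]1[C@H](NCc2cccs2)C[C@H]2C[C@@H]1C2(C)C` differs from compound 2 in one place: hydrogen in place of chloro on an aromatic carbon. Cut one bond further out, the change reads 5-chlorothiophen-2-yl to thiophen-2-yl. Going by the values given here, no step between measured compounds informs this change. Given that compound 1 and compound 2 sit together at 25000 nM despite different aromatic groups, the step of no change at the digits printed from compound 2 to compound 3 (within the scatter) is expected to stay within the scatter, with no direction. Compound 3 is therefore estimated at 25000 nM in this assay, between 12000 nM and 50000 nM.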

Compound 3, minimum cytotoxic concentration: 25000 nM
The estimate for compound 3 equals the measured number at the digits printed; the range from low to high includes it.
By their numbers in this assay, from the lowest: compounds 1, 2 and 3 (each within the scatter of the next).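

In this assay, the change from 5-chlorothiophen-2-yl to thiophen-2-yl gives no change at the digits printed from compound 2 to compound 3 (within the scatter), so the tolerance seen with compound 2 does not depend on chloro at this place on the aromatic ring. Hydrogen in place of 1-methylethenyl gives no change at the digits printed from compound 1 to compound 3 (within the scatter), so neither group on the aromatic ring separates from hydrogen in this read-out. No supporting finding is available to account for this result.

With all three compounds at one level, the data do not show whether any group at this aromatic carbon can shift the tolerated concentration. A carboxylic acid or an amine in place of chloro on that carbon remains an open test, as do changes to the shared core.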